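Cytotoxicity notes: step from compound 2 to compound 3

A few compounds are considered here, and "the series" means these few. Any claim that something is new, unique, unknown or untested is made for them only; others in the source may bear on it.

Compound 1 `CC(=O)Nc1cccc(-c2ccc(C(=O)N(Cc3cccc(OCCCCCC(=O)O)c3)C(C)C)cc2)c1` gives in an ADME assay on HEK293 cells (Homo sapiens) for cytotoxicity, read by CellTiter-Glo and resazurin assay, with a stated time of 72 h (a higher number here means that more compound is needed for the effect, a lower number that less compound is needed), the value > 26000 nM, which is a limit of the assay and not a number.
Compound 2 `Cc1nnc(-c2cccc(-c3ccc(C(=O)N(Cc4cccc(OCCCCCC(=O)O)c4)C(C)C)cc3)c2)o1` gives in this assay the value > 26000 nM, likewise a limit.

Compound 2 stands at the limit of > 26000 nM in this assay, at which 2 of the 2 values shown sit, so no number is known for it in this assay. Within the data shown here, the single measured step, a step that the two limits leave unreadable from compound 1 to compound 2, concerns a different group and cannot be read because both ends sit at the limit of > 26000 nM in this assay, at which 2 of the 2 values shown sit.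

Compound 3 `CC(C)N(Cc1cccc(OCCCCCC(=O)O)c1)C(=O)c1ccc(-c2c[nH]c3ccccc23)cc1` is not yet measured. It differs from compound 2 by 1H-indol-3-yl in place of 3-(5-methyl-1,3,4-oxadiazol-2-yl)phenyl on an aromatic carbon. Among the measured compounds shown here, no measured step bears directly on this change, and the one step available gives no readable size. With both measured compounds at the limit, the step expected is a step that the limit leaves unreadable from compound 2 to compound 3, none beyond the scatter. Compound 3 is therefore expected at 30000 nM, estimated within 8000 nM to 100000 nM, most likely reported again only as a limit.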

Compound 3, half-maximal effective concentration: > 26000 nM
Compound 3: only a limit was reported (the forecaster's own chance of this, stated with the estimate: 70%); the middle value lies beyond the limit too.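

No step among compound 1, compound 2 and compound 3 can be read, since each value is a limit of the assay and not a number: the limit of > 26000 nM in this assay, at which 3 of the 3 values shown sit.

What the compounds shown leave open is whether any of these groups on the aromatic carbon changes the read-out in this assay, and at what concentration any effect would appear.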